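Replacing the Alkynyl Side Chain of Compound 1

This account rests on a few compounds, and the source may have more. Where it says the series, first, only, none or still open, it means among the compounds named here.

In a functional assay on MCF7 cells (Homo sapiens) for antiproliferative activity, read by MTT assay, with a stated time of 24 h (on this read-out higher numbers stand for weaker inhibition and lower numbers for stronger inhibition), compound 1 `CCN(CC)CCNC(=O)C1CC(C(CC)(CC)c2ccc(C#CC(C)(O)CC)c(C)c2)=CN1CC` gives 2780 nM. For the measured compounds named here, compound 2 `CCN(CC)CCNC(=O)C1CC=C(C(CC)(CC)c2ccc(C#CC(O)C3CCCCC3)c(C)c2)N1CC` gives 2790 nM, so the two values lie within the scatter of each other and compound 1 stands level with the only other measured compound. Compound 3 `CCN(CC)CCNC(=O)C1CC(C(CC)(CC)c2ccc(CCC(O)(CC)CC)c(C)c2)=CN1CC` keeps the core of compound 1 and changes one group on an aromatic carbon, ortho to a methyl group and para to a large group: a group of 8 heavy atoms (7 carbon, 1 oxygen; no ring) in place of a group of 7 heavy atoms (6 carbon, 1 oxygen; no ring), on an aromatic carbon. The entering group is 3-ethyl-3-hydroxypentyl. Going by the values given here, no measured pair here differs in one place only, so the expectation rests on compound 1 at 2780 nM alone. No shift beyond the scatter is expected in this assay, and the estimated step is a 1.1-fold higher number from compound 1 to compound 3 (0.03 log units; within the scatter). For compound 3 the expected value is 3000 nM, with an estimated range from 1200 nM to 7500 nM.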

Compound 3, half-maximal inhibitory concentration: 3580 nM
Compound 3: the middle estimate sits 1.2-fold (0.08 log units) below what was measured, within the range that was stated.
By their numbers in this assay, from the lowest: compounds 1, 2 and 3 (each within the scatter of the next).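

In this assay, the exchange of the alkynyl side chain for 3-ethyl-3-hydroxypentyl on this aromatic carbon, ortho to a methyl group and para to a large group, gives a step that stays within the scatter (a 1.3-fold higher number from compound 1 to compound 3 (0.11 log units; within the scatter)). For this pair, then, the triple bond outside aromatic rings can go without a measurable loss of antiproliferative activity, which compound 2 could not show, as it differs from compound 1 in more than one place. No measurement at hand bears on this result.

The compounds shown leave open whether an amine or a carboxylic acid on the side chain, or a chain longer than 3-ethyl-3-hydroxypentyl, would move the value beyond the scatter at this position. They also leave open what a plain ethyl group without the hydroxyl would do there.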